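One stereocentre redrawn: what should compound 3 show?

This account rests on a few compounds, and the source may have more. Where it says the series, first, only, none or still open, it means among the compounds named here.

Measured so far in a physicochemical assay for solubility (on this read-out lower numbers stand for lower solubility and higher numbers for higher solubility), so far:
- compound 1 `O=C(c1cccc(Cl)c1)N1CCC(NS(=O)(=O)c2cc(S(=O)(=O)c3ccccc3)ccc2C(F)(F)F)CC1` gives 6300 nM
- compound 2 `CC(C)(C)OC(=O)N1CC[C@H](C(=O)N2CCC(NS(=O)(=O)c3cc(S(=O)(=O)c4ccccc4)ccc3C(F)(F)F)CC2)C1` gives 25000 nM

Compound 2 holds the higher of these two numbers. Going by the values given here, the only measured step, a 4.0-fold higher number from compound 1 to compound 2 (0.60 log units; beyond the scatter), puts 1-(tert-butoxycarbonyl)pyrrolidin-3-yl in place of 3-chlorophenyl on a carbonyl carbon, which is the exchange of one whole group for another.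

Compound 3 `CC(C)(C)OC(=O)N1CC[C@@H](C(=O)N2CCC(NS(=O)(=O)c3cc(S(=O)(=O)c4ccccc4)ccc3C(F)(F)F)CC2)C1` has not been measured. Its change from compound 2 is much smaller: the two compounds have the same atoms and bonds and differ only in configuration as drawn: 1 of 1 stereo elements differ; a stereocentre at a saturated ring carbon is drawn S in compound 2 and R in compound 3. The two compounds have the same atoms and bonds, and a stereocentre at a saturated ring carbon is drawn S in compound 2 and R in compound 3. S and R name the two possible arrangements around that carbon.

Among the compounds with values here, no measured pair here shows a change of configuration alone, so the one measured step bears only loosely, as a scale for a whole-group exchange. No step beyond the scatter is therefore expected in this assay, in either direction. The expected result is no change at the digits printed from compound 2 to compound 3 (within the scatter) on this estimate. For compound 3 the estimate is 25000 nM, with an expected range from 12000 nM to 50000 nM as its ends.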

Compound 3, solubility: 12500 nM
Beside the measured number, compound 3's estimate is 2.0-fold (0.30 log units) above it; the measured number falls inside the stated range.
By their numbers in this assay, from the lowest: compounds 1, 3 and 2 (each within the scatter of the next, the first and the last beyond it).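

In this assay, going by these compounds alone, redrawing the stereocentre at the saturated ring carbon from S to R gives a 2.0-fold lower number from compound 2 to compound 3 (0.30 log units; within the scatter): this is the first reading of configuration alone at this position, and it does not separate the two forms. The group exchange now reads less firmly than before, since the S form gave a 4.0-fold higher number from compound 1 to compound 2 (0.60 log units; beyond the scatter), whereas the R form gives a 2.0-fold higher number from compound 1 to compound 3 (0.30 log units; within the scatter), so the earlier step beyond the scatter cannot be claimed for 1-(tert-butoxycarbonyl)pyrrolidin-3-yl in both configurations. Should repeated measurements show a real difference between compound 2 and compound 3, only one structural source would be available to explain it: the fact that compounds 2 and 3 differ only in the configuration as drawn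

From the compounds shown here alone, this is a single pair of forms, so it remains open whether configuration at this carbon would count for as little with another group in place of tert-butoxycarbonyl, such as a free amine or an acetyl group. Going by these compounds, it is also open whether the same holds when the carbonyl carries a different saturated ring, such as a piperidin-3-yl group, which has its own stereocentre.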